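Replacing a side chain with a methyltetrazole on a shared core

This account rests on a few compounds, and the source may have more. Where it says the series, first, only, none or still open, it means among the compounds named here.

Measured compounds:
compound 1 `CC(C)(O)c1cc(-c2ccccc2)c2ccc(OCc3cccc(C4(O)CCOCC4)c3)cc2c1` 1500 nM
compound 2 `COC(C)c1cc(-c2ccccc2)c2ccc(OCc3cccc(C4(O)CCOCC4)c3)cc2c1` 1200 nM

In an assay on isolated protein with Polyunsaturated fatty acid 5-lipoxygenase (Homo sapiens) as the target (a lower number here means a stronger inhibitor, a higher number a weaker inhibitor), compound 2 gives 1200 nM and compound 1 gives 1500 nM; the two numbers sit within the scatter of each other, so neither can be called the stronger inhibitor. Among the measured compounds shown here, the step of a 1.3-fold lower number from compound 1 to compound 2 (0.10 log units; within the scatter) is the only measured step on the shared core, and it exchanged one group for another on an aromatic carbon without moving the number beyond the scatter. Compound 3 `Cn1nnnc1-c1cc(-c2ccccc2)c2ccc(OCc3cccc(C4(O)CCOCC4)c3)cc2c1` carries a further exchange at that place: 1-methyl-1H-tetrazol-5-yl in place of 1-methoxyethyl on an aromatic carbon. For the measured compounds named here, no measured step introduces a ring or anything resembling this group, so the single step on hand offers no reason to expect a shift beyond the scatter in this assay, though the range must stay wide. Compound 3 is therefore expected to give about 1500 nM, between 400 nM and 6000 nM. This estimate means a step of a 1.3-fold higher number from compound 2 to compound 3 (0.10 log units; within the scatter).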

Compound 3, half-maximal inhibitory concentration: 3000 nM
Estimate against measurement, compound 3: 2.0-fold (0.30 log units) below; low and high end bracket the measured number.
By their numbers in this assay, from the lowest: compounds 2, 1 and 3 (each within the scatter of the next, the first and the last beyond it).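

Unlike the exchange between the two open chains, putting the ring of 1-methyl-1H-tetrazol-5-yl in place of 1-methoxyethyl on this aromatic carbon gives a 2.5-fold higher number from compound 2 to compound 3 (0.40 log units; beyond the scatter) in this assay as the first step at this place to lie beyond the scatter, though only modestly. Set against 1-hydroxy-1-methylethyl, the same ring gives a 2.0-fold higher number from compound 1 to compound 3 (0.30 log units; within the scatter) and so cannot be told apart from that group, which means the change is readable against only one of the two chains. The position therefore accepts this five-membered aromatic ring with at most a modest change in the number, and no measurement on hand offers an explanation for the step.

As far as these compounds go, it remains open whether the methyl group on the ring matters, as a tetrazole without that methyl would show. From the compounds shown here alone, it is also open how an amine or a carboxylic acid at this place would fare in this assay on the shared core.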